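Aryl sulfonamide series: weak growth inhibition, compound 4 pending

This account rests on a few compounds, and the source may have more. Where it says the series, first, only, none or still open, it means among the compounds named here.

Measured so far:
- Compound 1 `O=S(=O)(Nc1ccc(Cl)cc1Cl)c1ccc(-c2cnc(C3CC3)o2)cc1`: in a functional assay on cells (leukaemia cell line, Homo sapiens) for inhibition, read by sulforhodamine B assay, with a stated time of 48 h (a lower number here means a stronger inhibitor of growth, a higher number a weaker inhibitor of growth), compound 1 gives 74500 nM.
- Compound 2 `O=S(=O)(Nc1ccc(F)c(Cl)c1)c1ccc(-c2cnc(C3CC3)o2)cc1`: compound 2 gives 73700 nM.
- Compound 3 `Cc1ccc(NS(=O)(=O)c2ccc(-c3cnc(C4CC4)o3)cc2)cc1C`: for compound 3 only a limit is reported, > 100000 nM.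

Compound 3 thus sits at the limit (the limit of > 100000 nM in this assay, at which 1 of the 3 values shown sits), with no number of its own. The steps reaching it, an at least 1.3-fold higher number from compound 1 to compound 3 (0.12 log units; that floor lies within the scatter) and an at least 1.3-fold higher number from compound 2 to compound 3 (0.13 log units; that floor lies within the scatter), are floors that lie within the scatter, as is a 1.0-fold lower number from compound 1 to compound 2 (0.00 log units; within the scatter).

Compound 4 `Cc1cc(F)cc(NS(=O)(=O)c2ccc(-c3cnc(C4CC4)o3)cc2)c1` differs from compound 3 by 3-fluoro-5-methylphenyl in place of 3,4-dimethylphenyl on a sulfonamide nitrogen. The measured steps that bear on this are the two into compound 3 and the halogen swap between compound 1 and compound 2, none of them beyond the scatter. The expected step in this assay is therefore none beyond the scatter, a number no higher from compound 3 to compound 4 (the limit leaves the size open). Compound 4 is estimated at 100000 nM, in the range 50000 nM to 200000 nM.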

Compound 4, concentration for total growth inhibition: 7250 nM
Estimate against measurement, compound 4: 14-fold (1.14 log units) above; measured number below the stated range.
By their numbers in this assay, from the lowest: compound 4; then compounds 2 and 1 (each within the scatter of the next). At a limit, above all of these: compound 3.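

For the compounds shown here, the aryl group on the sulfonamide nitrogen can move the read-out in this assay beyond the scatter, which the earlier compounds did not show: 3-fluoro-5-methylphenyl gives a 10-fold lower number from compound 1 to compound 4 (1.01 log units; beyond the scatter) and a 10-fold lower number from compound 2 to compound 4 (1.01 log units; beyond the scatter). Replacing 3,4-dimethylphenyl with the same group gives an at least 13-fold lower number from compound 3 to compound 4 (1.13 log units; beyond the scatter). Compound 3 carries only a limit, so this last step is a floor: the limit of > 100000 nM in this assay, at which 1 of the 4 values shown sits.

The compounds shown do not separate the contribution of the fluorine from that of the methyl in 3-fluoro-5-methylphenyl. As far as these compounds go, how a methoxy group or an amine in place of that fluorine would read remains open.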